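Thiophene to furan swap on the saturated ring carbon

A few compounds are considered here, and "the series" means these few. Any claim that something is new, unique, unknown or untested is made for them only; others in the source may bear on it.

Measured so far:
compound 1 `CCOC(=O)C1=C(C)N/C(=N\C#N)NC1c1ccsc1`: 29%
compound 2 `CC1=C(C(=O)OC(C)C)[C@@H](c2ccco2)N/C(=N/C#N)N1`: 2%

In an assay on cells for displacement of a labelled ligand from adenosine receptor A1 (Homo sapiens), with a stated time of 60 min, tested at 1 uM (a higher number here means more inhibition at the concentration tested (going by the name of the read-out), a lower number less inhibition), compound 1 gives 29%, the higher of the two numbers available; compound 2 gives 2%, a gap beyond the scatter. For the measured compounds named here, the two compounds differ in more than one place, so no single step between measured compounds is at hand, and the pair shows only its two values. Compound 3 `CCOC(=O)C1=C(C)N/C(=N\C#N)NC1c1ccoc1` differs from compound 1 by furan-3-yl in place of thiophen-3-yl on a saturated ring carbon. Going by the values given here, with no single-change step to lean on, a modest loss is expected, near the edge of the scatter, a number 11 percentage points lower from compound 1 to compound 3 (beyond the scatter). For compound 3 the estimate is 18% with a range from 5% to 32%.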

Compound 3, a percentage reported as inhibition, at one concentration (the size of the read-out at that concentration, not a potency): 28%
Beside the measured number, compound 3's estimate is 10 percentage points below it; measured number inside the range.
By their numbers in this assay, from the lowest: compound 2; then compounds 3 and 1 (each within the scatter of the next).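

In this assay furan-3-yl in place of thiophen-3-yl on a saturated ring carbon reads as a number 1 percentage points lower from compound 1 to compound 3 (within the scatter) and so the two rings cannot be told apart at this position. For the compounds shown here, this is the first single-change step, which the earlier pair, differing in more than one place, could not give. Nothing on hand explains this result. 

The compounds shown leave open whether a phenyl ring or a simple alkyl chain on this carbon would read the same. Also open, going by these compounds, is what a carboxylic acid would do in place of the ethoxycarbonyl group.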